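The source may hold more compounds than are shown below. What is called first, only, known or untested is meant among the compounds shown, and "the series" means these compounds.

Compound 1 (`CCc1nc2c(C)cc(-c3ccc(CN4CCC[C@H]4CO)cc3)cn2c1NC(=O)OCc1cc(Cl)cc(Cl)c1`): "nd" (no result reported)
Compound 2 (`CCc1nc2c(C)cc(-c3ccc(CN4CCN(C)CC4)cc3)cn2c1NC(=O)OCc1cc(Cl)cc(Cl)c1`): 5780 nM
Compound 3 (`CCc1nc2c(C)cc(-c3ccc(CN4CCC(C)CC4)cc3)cn2c1NC(=O)OCc1cc(Cl)cc(Cl)c1`): 3980 nM

These compounds share one core and differ in the group on a saturated chain carbon bound to an aromatic carbon. Within the data shown here, in a functional assay on MCF7 cells (Homo sapiens) for inhibition, read by MTT assay, with a stated time of 72 h (a lower number here means a stronger inhibitor, a higher number a weaker inhibitor), compound 3 reads 3980 nM and compound 2 reads 5780 nM as the only two numbers available, and these lie within the usual scatter of each other. Compound 1 has no reported result, so it offers no guidance.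

Compound 4 (`CCc1nc2c(C)cc(-c3ccc(CNCCO)cc3)cn2c1NC(=O)OCc1cc(Cl)cc(Cl)c1`) has not yet been measured. It differs from compound 3 at that same place, with (2-hydroxyethyl)amino in place of 4-methylpiperidin-1-yl ((2-hydroxyethyl)amino in place of 4-methylpiperidin-1-yl on a saturated chain carbon bound to an aromatic carbon). The ring is therefore replaced by an open chain.

Among the measured compounds shown here, only one measured step bears on this change (a 1.5-fold lower number from compound 2 to compound 3 (0.16 log units; within the scatter)), and it stayed within the scatter. For the measured compounds named here, that step swaps one six-membered ring for another, so it is a weak guide to replacing the ring with a chain, and no measured pair covers such a replacement. No step beyond the scatter is therefore expected in this assay, and the estimated step (a 1.3-fold higher number from compound 3 to compound 4 (0.10 log units; within the scatter)) is small. Compound 4 is estimated at 5000 nM (expected range 2000 nM to 12500 nM).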

Compound 4, half-maximal inhibitory concentration: > 20000 nM
Compound 4: a limit, no number; the forecaster's own chance of this, stated with the estimate: 10%; at least 4.0-fold (0.60 log units) between middle value and limit.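

The reading for compound 4 in this assay is a limit of the assay and not a number, so the true size of the loss stays unknown: the limit of > 20000 nM in this assay, at which 1 of the 4 values shown sits.

Even so, the limit is enough to show that this position does respond to its group, which the earlier pair could not show, as their one step, a 1.5-fold lower number from compound 2 to compound 3 (0.16 log units; within the scatter), exchanged one six-membered ring for another. Replacing either ring with the open (2-hydroxyethyl)amino group gives an at least 5.0-fold higher number from compound 3 to compound 4 (0.70 log units; beyond the scatter) and an at least 3.4-fold higher number from compound 2 to compound 4 (0.53 log units; beyond the scatter), so on a saturated chain carbon bound to an aromatic carbon, this open chain goes with a clearly weaker inhibitor than either ring.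

This single change removes the ring, shortens the group and adds a hydroxyl, and the compounds shown cannot separate these differences from one another. An ethylamino group, which has a chain but no hydroxyl, and a morpholine ring, which has an oxygen but stays a ring, would help show which difference goes with the weaker reading.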